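Changing the Amine Substituent: Cytotoxicity Expected for Compound 4

The source may hold more compounds than are shown below. What is called first, only, known or untested is meant among the compounds shown, and "the series" means these compounds.

Compound 1 `Cc1ccc2[nH]c(=O)c(CN(Cc3ccc(N(C)C)cc3)Cc3ccc(C(C)(C)C)cc3)cc2c1` gives in a toxicity assay on MDCK cells (Canis lupus familiaris) for cytotoxicity, read by crystal violet staining, with a stated time of 48 h; on this read-out lower numbers stand for higher toxicity in this test and higher numbers for lower toxicity in this test > 5000 nM, which is a limit of the assay.
Compound 2 `CCc1ccc2[nH]c(=O)c(CN(Cc3ccc(C(C)(C)C)cc3)[C@@H](C)c3ccc(OC)cc3)cc2c1` gives in this assay > 5000 nM, again a limit of the assay.
Compound 3 `COc1ccc([C@H](C)N(Cc2ccc(C(C)(C)C)cc2)Cc2cc3cc(OC)ccc3[nH]c2=O)cc1` gives in this assay 4100 nM.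

Among the compounds with values here, compound 3 thus holds the only number among the three, while the limit of > 5000 nM in this assay, at which 2 of the 3 values shown sit, describes the others. Within the data shown here, the one measured step, an at least 1.2-fold lower number from compound 2 to compound 3 (0.08 log units; that floor lies within the scatter), concerns a methoxy in place of an ethyl on an aromatic carbon and has a floor that lies within the scatter.

Compound 4 `COc1ccc2[nH]c(=O)c(CN(Cc3ccc(N(C)C)cc3)Cc3ccc(C(C)(C)C)cc3)cc2c1` has not been measured. It differs from compound 3 by 4-(dimethylamino)benzyl in place of 1-(4-methoxyphenyl)ethyl on an amine nitrogen. Among the measured compounds shown here, no measured step touches this position. Compound 1 carries the same 4-(dimethylamino)benzyl as compound 4, and compound 1 gives only a limit. Nothing shown points to a step beyond the scatter in this assay in either direction.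

Compound 4 is therefore expected to give 5000 nM, in a range from 2500 nM to 10000 nM. The step of a 1.2-fold higher number from compound 3 to compound 4 (0.09 log units; within the scatter) that this estimate implies is expected to remain within the scatter, and a limit rather than a number is thought likely.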

Compound 4, half-maximal cytotoxic concentration: 8500 nM
Compound 4: middle estimate off by 1.7-fold (0.23 log units), on the low side, and the stated range covers the measured number.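

Within the data shown here, the exchange on the amine nitrogen gives the first readable step at this position: in this assay, 4-(dimethylamino)benzyl in place of 1-(4-methoxyphenyl)ethyl brings a 2.1-fold higher number from compound 3 to compound 4 (0.32 log units; beyond the scatter), and the higher number stands for lower toxicity in this test. The two groups match in their counts of heavy atoms, hydrogen-bond donors and hydrogen-bond acceptors, and each carries one six-membered aromatic ring of carbon only and no net charge. They differ in that the entering group holds a nitrogen where the leaving group holds an oxygen, and only the leaving group has a defined stereocentre. The other new step, the one between compound 1 and compound 4, cannot be read: the limit of > 5000 nM in this assay, at which 2 of the 4 values shown sit.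

On these data alone, what a 4-methoxybenzyl or a 4-morpholinobenzyl group would give on this amine nitrogen remains open, so the step cannot yet be divided between the dimethylamino group and the loss of the stereocentre. Also open, as far as these compounds go, is whether the opposite stereocentre in 1-(4-methoxyphenyl)ethyl, or an ethoxy group on the aromatic carbon of the shared core, would shift the number in this assay.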